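A Longer Unsaturated Ketone Arm on a Lactone Core

This account rests on a few compounds, and the source may have more. Where it says the series, first, only, none or still open, it means among the compounds named here.

Compound 1 `C[C@H]1C[C@@H]2OC(=O)[C@H](C)[C@H]2CC=C1C(=O)O` carries a carboxylic acid on the shared core. In a functional assay on BV-2 cells (Mus musculus, strain C57BL6/J) for inhibition, read by Griess assay, with a stated time of 24 h (a lower number here means a stronger inhibitor, a higher number a weaker inhibitor), compound 1 gives only a limit, > 10000 nM, not a number. Compound 2 `C[C@H]1C[C@@H]2OC(=O)[C@H](C)[C@H]2CC=C1C=O` carries a formyl group in its place; in this assay compound 2 likewise gives only a limit, > 10000 nM. The step between them, a step that the two limits leave unreadable from compound 1 to compound 2, therefore cannot be read in size, since (the limit of > 10000 nM in this assay, at which 2 of the 2 values shown sit). Compound 3 `CC(=O)/C=C/C1=CC[C@H]2[C@H](C[C@@H]1C)OC(=O)[C@@H]2C` differs from compound 2 by 2-acetylethenyl in place of formyl on a double-bonded ring carbon. No measured step bears directly on this change, and the one step shown is unreadable. With both measured values sitting at the limit, compound 3 is expected to stand close to compound 2, so the step that the limit leaves unreadable from compound 2 to compound 3 is an estimate with little support behind it. Compound 3 is estimated at 12000 nM, within a range of 3000 nM to 50000 nM, and is expected most likely to be reported again only as a limit.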

Compound 3, half-maximal inhibitory concentration: 3700 nM
Compound 3: middle estimate off by 3.2-fold (0.51 log units), on the high side, within the range that was stated.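

In this assay, the double-bonded ring carbon of the seven-membered ring now gives a readable response to a change of group: there is an at least 2.7-fold lower number from compound 2 to compound 3 (0.43 log units; beyond the scatter), and there is also an at least 2.7-fold lower number from compound 1 to compound 3 (0.43 log units; beyond the scatter). The group at this position can therefore move the result beyond the scatter, which the comparison of carboxy with formyl could not show. Both steps are only minimum sizes, and their full size stays unknown because the starting compounds give no number: the limit of > 10000 nM in this assay, at which 2 of the 3 values shown sit.

The 2-acetylethenyl group differs from formyl in more than one feature, and the compounds shown do not separate the effect of its ketone carbonyl from that of its added double bond. From the compounds shown here alone, how a saturated 3-oxobutyl chain, an ester or an amine at this position would read in this assay stays open.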